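Chain Extension at Two Places in a Benzimidazole-Type Series

A few compounds are considered here, and "the series" means these few. Any claim that something is new, unique, unknown or untested is made for them only; others in the source may bear on it.

Of the compounds shown here, three have been measured in a functional assay (aorta) with Oryctolagus cuniculus as the target; on this read-out lower numbers stand for tighter binding and higher numbers for weaker binding. Compound 2, `CCCc1nc2c(C)ccnc2n1Cc1cc(Cl)c(O)c(Cl)c1`, gives 1.26 nM. Compound 1, `CCCCc1nc2c(C)ccnc2n1Cc1cc(Cl)c(O)c(Cl)c1`, gives 10 nM. The change between them, (methyl in place of hydrogen on a saturated chain carbon, three bonds along the chain from an aromatic carbon), produced a 7.9-fold higher number from compound 2 to compound 1 (0.90 log units; beyond the scatter). Compound 3, `CSc1nc2c(C)ccnc2n1Cc1ccc(-c2ccccc2C(=O)O)cc1`, gives 10 nM in this assay, which stands level with compound 1; the difference between the core of compound 3 and the core of compound 2 is not broken down here.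

Compound 4, `CCSc1nc2c(C)ccnc2n1Cc1ccc(-c2ccccc2C(=O)O)cc1`, has not yet been measured. It differs from compound 3 by methyl in place of hydrogen on a saturated chain carbon bound to a sulfur. Among the compounds with values here, this is the same kind of change as the one from compound 2 to compound 1, but the place is not the same: there the methyl entered on a saturated chain carbon three bonds along the chain from an aromatic carbon, whereas here it enters on a saturated chain carbon bound to a sulfur. Because the earlier step gave a 7.9-fold higher number from compound 2 to compound 1 (0.90 log units; beyond the scatter), a weakening is expected from compound 3 to compound 4 as well, though with less confidence given the different place and core; the step expected is a 2.0-fold higher number from compound 3 to compound 4 (0.30 log units; within the scatter). Compound 4 is therefore estimated at 20 nM, with a likely range from 5 nM to 80 nM.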

Compound 4, dissociation constant: 5.01 nM
Compound 4: the middle estimate sits 4.0-fold (0.60 log units) above what was measured; measured number inside the range.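

In this assay the methyl entering on a saturated chain carbon bound to a sulfur gives a 2.0-fold lower number from compound 3 to compound 4 (0.30 log units; within the scatter) and so leaves methylsulfanyl and ethylsulfanyl not told apart on this core. Set beside the earlier step, the same kind of change did not carry over from one core to the other: the same change on two cores in this assay, a 7.9-fold higher number (0.90 log units; beyond the scatter) from compound 2 to compound 1 and a 2.0-fold lower number (0.30 log units; within the scatter) from compound 3 to compound 4, 16-fold (1.20 log units) apart, beyond the scatter of two such steps

This shows that adding a methyl to a chain cannot be assumed to have the same result on both cores, but it does not show whether the gap comes from the core or from the place, since the two pairs differ in both at once, and two pairs give no rule for other members of the series.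

The compounds shown leave open whether a longer chain, such as propylsulfanyl, would stay level with methylsulfanyl on the core of compound 3. They also leave open how the two cores would compare if each carried the same chain, for instance ethylsulfanyl on the core of compound 2.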